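The compounds below may be only part of what the source reports. "The series", "measured", "known", "first", "only" and "open" are said of these compounds alone.

For the measured compounds named here, compound 1, with the structure `Cc1cc(Cl)ccc1Nc1ncc(C(F)(F)F)c(N2Cc3cccc(N(C)S(C)(=O)=O)c3C2)n1`, is the weaker of the two compounds measured so far: in a functional assay on HepG2 cells (Homo sapiens) for antiproliferative activity, read by spectrophotometry, with a stated time of 2 days (on this read-out lower numbers stand for stronger inhibition of growth and higher numbers for weaker inhibition of growth), compound 1 gives 19600 nM. Compound 2, the structure `COc1cc(N2CCN(C(C)=O)CC2)ccc1Nc1ncc(C(F)(F)F)c(N2Cc3cccc(N(C)S(C)(=O)=O)c3C2)n1`, differs from compound 1 in more than one place, and in this assay compound 2 gives 3800 nM, a lower number than compound 1 that lies beyond the usual scatter. Compound 3, with the structure `CN(c1cccc2c1CN(c1nc(Nc3cc(Cl)cc(C(F)(F)F)c3)ncc1C(F)(F)F)C2)S(C)(=O)=O`, has not yet been measured. It differs from compound 1 in a single place: 3-chloro-5-(trifluoromethyl)phenyl in place of 4-chloro-2-methylphenyl on a nitrogen on an aromatic ring. Going by the values given here, no measured pair shows this change by itself, so what it does to growth inhibition is not known from these data. Compound 3 is expected to give a number close to that of compound 1, with a step of a 1.6-fold lower number from compound 1 to compound 3 (0.21 log units; within the scatter) that may not exceed the scatter. The estimate for compound 3 in this assay is 12000 nM, within a range from 3500 nM to 40000 nM.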

Compound 3, concentration for 50% growth inhibition: 9900 nM
Compound 3: middle estimate off by 1.2-fold (0.08 log units), on the high side; the measured number falls inside the stated range.
By their numbers in this assay, from the lowest: compound 2; then compounds 3 and 1 (each within the scatter of the next).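

In this assay, for the compounds shown here, 3-chloro-5-(trifluoromethyl)phenyl in place of 4-chloro-2-methylphenyl on a nitrogen on an aromatic ring gives a 2.0-fold lower number from compound 1 to compound 3 (0.30 log units; within the scatter), the first step at this position seen by itself. The position thus takes an aryl group of 11 heavy atoms instead of 8, carrying trifluoromethyl and no methyl, while growth inhibition stays within the scatter of that of compound 1. Nothing at hand offers an explanation for this outcome.

The compounds shown leave open whether an amine or a carboxylic acid on this phenyl ring would shift the number beyond the scatter. They also leave open how the methyl and the trifluoromethyl each count alone, since this step exchanges the whole substituted ring.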